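Replacing 4-(trifluoromethyl)phenyl on the hydroxy compound

The source may report more compounds than this note shows. Statements on the series, on what has been measured and on what is new or still open speak of the compounds shown alone.

In a functional assay on A2780 cells (Homo sapiens) for inhibition, read by sulforhodamine B assay (a higher number here means a weaker inhibitor of growth, a lower number a stronger inhibitor of growth), compound 1 (`COc1ccc(-c2ccc(-c3ccc(-c4nc5cc(C)ccc5[nH]4)cc3)cc2)cc1OC`) gives 2130 nM as the lowest of three numbers and compound 2 (`FC(F)(F)c1ccc(-c2ccc(-c3ccc(-c4nc5ccccc5[nH]4)cc3)cc2)cc1`) gives 100000 nM as the highest. Compound 3 (`Oc1cccc2[nH]c(-c3ccc(-c4ccc(-c5ccc(C(F)(F)F)cc5)cc4)cc3)nc12`) stands between them at 6100 nM as the second highest number.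

The next compound is compound 4 (`COc1ccc(-c2ccc(-c3ccc(-c4nc5c(O)cccc5[nH]4)cc3)cc2)cc1OC`). The change is 3,4-dimethoxyphenyl in place of 4-(trifluoromethyl)phenyl on an aromatic carbon with 3,4-dimethoxyphenyl in place of 4-(trifluoromethyl)phenyl on an aromatic carbon, para to a large group.

For the measured compounds named here, no measured step makes this exchange alone. Going by the values given here, the only measured step is a 16-fold lower number from compound 2 to compound 3 (1.21 log units; beyond the scatter) for hydroxy in place of hydrogen on an aromatic carbon, a large step, and compound 4 keeps that hydroxy. The closest evidence is compound 1, which carries 3,4-dimethoxyphenyl and gives 2130 nM while lacking the hydroxy. Going by these compounds, compound 2 gives 100000 nM, and the number of compound 1 is far lower, but compound 1 also differs by a methyl group, so the size of the exchange alone remains unknown.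

A moderate fall is therefore expected, and the estimated step is a 5.1-fold lower number from compound 3 to compound 4 (0.71 log units; beyond the scatter) toward stronger growth inhibition. For compound 4 the estimated value is 1200 nM with an expected range from 250 nM to 6000 nM in this measurement.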

Compound 4, concentration for 50% growth inhibition: 2710 nM
Beside the measured number, compound 4's estimate is 2.3-fold (0.35 log units) below it; low and high end bracket the measured number.
By their numbers in this assay, from the lowest: compounds 1 and 4 (each within the scatter of the next); then compound 3; then compound 2.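

With the hydroxy kept in place, the exchange of 4-(trifluoromethyl)phenyl for 3,4-dimethoxyphenyl can now be read on its own: in this assay it gives a 2.3-fold lower number from compound 3 to compound 4 (0.35 log units; beyond the scatter) as a modest step that lies beyond the usual scatter. The aryl group at this place therefore matters, though this step is smaller in class than the large one seen for adding the hydroxy, a 16-fold lower number from compound 2 to compound 3 (1.21 log units; beyond the scatter). With 3,4-dimethoxyphenyl present, 4-hydroxy-1H-benzimidazol-2-yl in place of 5-methyl-1H-benzimidazol-2-yl gives a 1.3-fold higher number from compound 1 to compound 4 (0.10 log units; within the scatter), so the two compounds cannot be told apart in this measurement, and nothing measured here explains either result.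

For the compounds shown here, what the hydroxy does alone in the 3,4-dimethoxyphenyl series stays open, as the only comparison available also exchanges the methyl group, and a single pair cannot show whether the gain from hydroxy depends on the aryl group. Also open, going by these compounds, is how an amine or a carboxylic acid on this six-membered aromatic ring, in place of the two methoxy groups, would read in this assay.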